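Replacing the Benzyl Group in a Glutamate Receptor Series

The compounds below may be only part of what the source reports. "The series", "measured", "known", "first", "only" and "open" are said of these compounds alone.

Compound 1: `Clc1cnc(N2CCN(Cc3nc4ccccc4n3Cc3ccccc3)CC2)nc1`, 126 nM
Compound 2: `FC(F)(F)c1ccc(Cl)nc1N1CCN(Cc2nc3ccccc3n2Cc2ccccc2)CC1`, 126 nM
Compound 3: `COCCn1c(CN2CCN(c3ncc(Cl)cn3)CC2)nc2ccccc21`, to be measured

In an assay on CHO cells with metabotropic glutamate receptor 2 (Homo sapiens) as the target, read by FLIPR (a higher number here means that more compound is needed for the effect, a lower number that less compound is needed), compound 1 gives 126 nM. Its only measured neighbour is compound 2, which in this assay gives 126 nM, so compound 1 stands level with compound 2 at the digits shown. Among the compounds with values here, the one step measured so far, no change at the digits printed from compound 1 to compound 2 (within the scatter), swaps 6-chloro-3-(trifluoromethyl)pyridin-2-yl for 5-chloropyrimidin-2-yl on an amine nitrogen in a ring and shows no change beyond the scatter.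

Compound 3 changes a different part of the shared core: methoxymethyl in place of phenyl on a saturated chain carbon bound to an aromatic nitrogen. Cut one bond further out, this reads benzyl to 2-methoxyethyl. Within the data shown here, no measured step touches this position, so the step from compound 1 to compound 2 offers only indirect guidance: it shows that at least one part of compound 1 tolerates a change of group without loss. On these data alone, whether the group on the aromatic nitrogen is equally tolerant is unknown. The expected step is a 2.0-fold higher number from compound 1 to compound 3 (0.30 log units; within the scatter), leaning toward a modest loss with wide uncertainty. For compound 3 the estimate in this assay is 250 nM, ranging from 80 nM to 800 nM.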

Compound 3, half-maximal effective concentration: 501 nM
Estimate against measurement, compound 3: 2.0-fold (0.30 log units) below; the range from low to high includes it.
By their numbers in this assay, from the lowest: compounds 1 and 2 (each within the scatter of the next); then compound 3.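

In this assay, within the data shown here, methoxymethyl in place of phenyl on a saturated chain carbon bound to an aromatic nitrogen gives a 4.0-fold higher number from compound 1 to compound 3 (0.60 log units; beyond the scatter), the first step in this set to go beyond the scatter, whereas the earlier change elsewhere on the shared core gave no change at the digits printed from compound 1 to compound 2 (within the scatter). The loss is modest, and compound 3 still gives 501 nM, so the phenyl ring is not essential for a measurable effect in this assay, although swapping it for methoxymethyl does come at a cost. This one change removes an aromatic ring, reduces the group from 6 heavy atoms to 3 and adds a hydrogen-bond acceptor, and no available evidence shows which of these differences accounts for the step.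

The compounds shown cannot separate those differences, and a cyclohexylmethyl group or a plain butyl chain at this place would help to tell the loss of the aromatic ring from the arrival of the oxygen. Also open, on these data alone, is whether 2-methoxyethyl would cost the same on the core of compound 2, which carries 6-chloro-3-(trifluoromethyl)pyridin-2-yl.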